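Trading a fluorinated diol for a sulfoximine on the aryl ring

The compounds below may be only part of what the source reports. "The series", "measured", "known", "first", "only" and "open" are said of these compounds alone.

Compound 2 `CC#C[C@H]1CN(S(=O)(=O)c2ccc(N)nc2)CCN1c1ccc([C@@](O)(CO)C(F)(F)F)cc1` holds the lower of the two numbers seen so far: in an assay on cells (Hepatocyte) for inhibition of glucokinase regulatory protein (Mus musculus), with stated times of 20 min and 40 min (on this read-out higher numbers stand for an effect only at larger amounts of compound and lower numbers for an effect already at smaller amounts), compound 2 gives 89 nM, while compound 1 `CC#C[C@H]1CN(S(=O)(=O)c2ccc(N)nc2)CCN1c1ccc(S(=O)(=O)NC)cn1` gives 381 nM, a gap beyond the scatter. Compound 3 `CC#C[C@H]1CN(S(=O)(=O)c2ccc(N)nc2)CCN1c1ccc(S(=O)(=NC)C(F)(F)F)cc1` differs from compound 2 by a group of 8 heavy atoms (2 carbon, 1 nitrogen, 1 oxygen, 3 fluorine, 1 sulfur; no ring) in place of a group of 8 heavy atoms (3 carbon, 2 oxygen, 3 fluorine; no ring), on an aromatic carbon. Among the measured compounds shown here, no measured pair of this kind exists, so the step is expected to be small, with no direction beyond the scatter; the estimate for compound 3 in this assay is 120 nM, within 35 nM to 400 nM, meaning an expected step of a 1.3-fold higher number from compound 2 to compound 3 (0.13 log units; within the scatter).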

Compound 3, half-maximal effective concentration: 2060 nM
The estimate for compound 3 lay 17-fold (1.23 log units) below the measured number; measured number above the stated range.
By their numbers in this assay, from the lowest: compound 2; then compound 1; then compound 3.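

In this assay the exchange on this aromatic carbon gives a 23-fold higher number from compound 2 to compound 3 (1.36 log units; beyond the scatter) and so shows that this position does not treat two groups of 8 heavy atoms alike. Matching the size of the group does not preserve the number here, and the entering group has 0 hydrogen-bond donors against 2 in the group that leaves. Nothing measured here explains the rise.

Still open, as far as these compounds go, is which part of the fluorinated diol matters, and whether a lone hydroxymethyl or a primary amine on this carbon would hold the number.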